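Replacing 3-fluoropyridin-2-yl in compound 3

The source may hold more compounds than are shown below. What is called first, only, known or untested is meant among the compounds shown, and "the series" means these compounds.

In a physicochemical assay for solubility, read by HPLC, measured as thermodynamic solubility, with a stated time of 4 h, at pH 6.8 (on this read-out higher numbers stand for higher solubility and lower numbers for lower solubility), compound 1 `Cn1c(COc2cccc(C(=O)O)c2)nc2ccc(Oc3ccccn3)cc21` gives 62 ug/mL, compound 2 `Cc1cccnc1Oc1ccc2nc(COc3cccc(C(=O)O)c3)n(C)c2c1` gives 37 ug/mL and compound 3 `Cn1c(COc2cccc(C(=O)O)c2)nc2ccc(Oc3ncccc3F)cc21` gives 7.1 ug/mL, the lowest of the three numbers. Compound 4 `Cc1ccc(C)c(Oc2ccc3nc(COc4cccc(C(=O)O)c4)n(C)c3c2)n1` has not yet been measured. Its difference from compound 3 is 3,6-dimethylpyridin-2-yl in place of 3-fluoropyridin-2-yl on an oxygen on an aromatic ring: 3,6-dimethylpyridin-2-yl stands in place of 3-fluoropyridin-2-yl on an oxygen on an aromatic ring.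

Among the measured compounds shown here, three measured steps bear on this change. The most direct is a 5.2-fold lower number from compound 2 to compound 3 (0.72 log units; beyond the scatter), where fluoro takes the place of methyl on an aromatic carbon. Compound 4 loses the fluoro and carries methyl groups, so this step suggests a move in the opposite direction, towards higher numbers. The step of an 8.7-fold lower number from compound 1 to compound 3 (0.94 log units; beyond the scatter), with fluoro in place of hydrogen, points the same way. The step of a 1.7-fold lower number from compound 1 to compound 2 (0.22 log units; within the scatter), with methyl in place of hydrogen, suggests that one methyl need not cost much. For the measured compounds named here, no measured compound carries two methyl groups on this ring, so the second methyl remains untested.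

The expected change is a 3.1-fold higher number from compound 3 to compound 4 (0.49 log units; beyond the scatter), a modest rise beyond the scatter. For compound 4 the estimated value in this assay is 22 ug/mL, with an expected range from 7 ug/mL to 65 ug/mL.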

Compound 4, solubility: 85 ug/mL
The estimate for compound 4 lay 3.9-fold (0.59 log units) below the measured number, outside the stated range (above it).
By their numbers in this assay, from the lowest: compound 3; then compounds 2, 1 and 4 (each within the scatter of the next, the first and the last beyond it).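

In this assay the change at this oxygen gives a 12-fold higher number from compound 3 to compound 4 (1.08 log units; beyond the scatter) and sets compound 3 apart, beyond the scatter, from all three other compounds, so that only the 3-fluoropyridin-2-yl compound stands clearly low. The second methyl group, which had no measurement behind it until now, gives a 2.3-fold higher number from compound 2 to compound 4 (0.36 log units; beyond the scatter) and so registers where the first one did not, that earlier step being a 1.7-fold lower number from compound 1 to compound 2 (0.22 log units; within the scatter) and lying within the scatter. Carrying both methyl groups does not separate the ring from plain pyridin-2-yl, since a 1.4-fold higher number from compound 1 to compound 4 (0.14 log units; within the scatter) also lies within the scatter, which leaves compounds 1 and 4 indistinguishable on this read-out.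

The compounds shown offer no measurement that speaks to the cause of these steps. They also leave open whether the low number of compound 3 is particular to fluoro or would recur with chloro, methoxy or an amine on this ring, and whether the second methyl group would give the same step without the first.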